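This account rests on a few compounds, and the source may have more. Where it says the series, first, only, none or still open, it means among the compounds named here.

Measured in a functional assay on Lu cells (Homo sapiens) for antiproliferative activity; on this read-out lower numbers stand for stronger inhibition and higher numbers for weaker inhibition:

compound 1 `COc1cc(/C=C/C(=O)c2ccc(OCCn3cc(CN4C(=O)/C=C/C(C)(C)C/C=C(\C)CC/C=C/4C)nn3)cc2O)cc(OC)c1OC`: 1.28 ug/mL
compound 2 `C/C1=C\CC(C)(C)/C=C/C(=O)N(Cc2cn(CCOc3ccc(C(=O)/C=C/c4ccc(C)cc4)c(O)c3)nn2)/C(C)=C/CC1`: 0.91 ug/mL
compound 3 `COc1cc(/C=C/C(=O)c2ccc(OCCCN3C(=O)/C=C/C(C)(C)C/C=C(\C)CC/C=C/3C)cc2)cc(OC)c1OC`: 1.01 ug/mL

All three values lie within the scatter of one another. Compound 1 and compound 3 share no single counted difference; the difference between their cores is not broken down here. From compound 1 to compound 2 the change is 4-methylphenyl in place of 3,4,5-trimethoxyphenyl on a double-bonded chain carbon bound to a double-bonded chain carbon, which gave a 1.4-fold lower number from compound 1 to compound 2 (0.15 log units; within the scatter).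

Compound 4 `C/C1=C\CC(C)(C)/C=C/C(=O)N(CCCOc2ccc(C(=O)/C=C/c3ccc(C)cc3)cc2)/C(C)=C/CC1` awaits measurement in this assay. It differs from compound 3 by 4-methylphenyl in place of 3,4,5-trimethoxyphenyl on a double-bonded chain carbon bound to a double-bonded chain carbon, the same change as the one carried out in the other pair, at a place described in the same words. For compound 4 a step of about a 1.3-fold lower number from compound 3 to compound 4 (0.13 log units; within the scatter) is expected, resting on the earlier step of a 1.4-fold lower number from compound 1 to compound 2 (0.15 log units; within the scatter) applied to the value of compound 3, 1.01 ug/mL. Compound 4 is therefore estimated at 0.75 ug/mL, with a likely range from 0.4 ug/mL to 1.5 ug/mL.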

Compound 4, half-maximal inhibitory concentration: 1.18 ug/mL
Compound 4: the middle estimate sits 1.6-fold (0.20 log units) below what was measured, within the range that was stated.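

Swapping 3,4,5-trimethoxyphenyl for 4-methylphenyl on the core of compound 3 gives a 1.2-fold higher number from compound 3 to compound 4 (0.07 log units; within the scatter) in this assay. Set beside the earlier step, the two cores give no sign that the outcome of this change depends on the core: the same change on two cores in this assay, a 1.4-fold lower number (0.15 log units; within the scatter) from compound 1 to compound 2 and a 1.2-fold higher number (0.07 log units; within the scatter) from compound 3 to compound 4, 1.6-fold (0.22 log units) apart, within the scatter of two such steps. Among these compounds, this shows only that the change stays within the scatter on both cores; it does not show a real effect of the change in either direction, and two pairs cannot establish that it would behave alike on other cores.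

Still open, from the compounds shown here alone, is whether a group carrying an amine or a carboxylic acid in place of 4-methylphenyl would give a step beyond the scatter. Also open, going by these compounds, is how a longer chain in the linker of compound 4 would read in this assay.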